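Replacing 2-Bromophenyl with 3-Methylphenyl

A few compounds are considered here, and "the series" means these few. Any claim that something is new, unique, unknown or untested is made for them only; others in the source may bear on it.

In a functional assay on K562 cells (Homo sapiens) for inhibition, read by trypan blue exclusion, with a stated time of 48 h (a lower number here means a stronger inhibitor, a higher number a weaker inhibitor), compound 1 (`Cc1ccc(NC(=O)/C=C/c2ccccc2)c(C(N)=O)c1`) gives 5500 nM, and compound 2 (`NC(=O)c1cc(Cl)ccc1NC(=O)/C=C/c1ccccc1Br`) gives 10000 nM. These two values lie within the usual scatter of each other, so compound 2 does not stand apart from compound 1. Compound 3 (`Cc1cccc(/C=C/C(=O)Nc2ccc(Cl)cc2C(N)=O)c1`) carries 3-methylphenyl in place of 2-bromophenyl on a double-bonded chain carbon bound to a double-bonded chain carbon. For the measured compounds named here, no measured pair shows the effect of this swap, so no change beyond the scatter is expected, and the expected step is a 1.3-fold lower number from compound 2 to compound 3 (0.12 log units; within the scatter). Compound 3 is estimated at 7500 nM, with an expected range from 2500 nM to 22000 nM.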

Compound 3, half-maximal inhibitory concentration: > 10000 nM
Compound 3: no number, only a limit; the forecaster's own chance of this, stated with the estimate: 10%; at least 1.3-fold (0.12 log units) between middle value and limit.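

In this assay compound 3 gives > 10000 nM, a limit of the assay and not a number. On this double-bonded chain carbon, 3-methylphenyl in place of 2-bromophenyl brings a number no lower from compound 2 to compound 3 (the limit leaves the size open), so this swap yields no stronger inhibitor. The result sits at the edge of the values shown: the limit of > 10000 nM in this assay, at which 1 of the 3 values shown sits.

How far compound 3 lies from compound 2 cannot be read. On these data alone, whether an amine or a carboxylic acid at this place would give a lower number remains open.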